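A Phenylethyl Amide Joins a Weakly Active Series

The source may hold more compounds than are shown below. What is called first, only, known or untested is meant among the compounds shown, and "the series" means these compounds.

Measured in a functional assay on MCF7 cells (Homo sapiens) for antiproliferative activity, read by MTT assay, with a stated time of 24 h; on this read-out higher numbers stand for weaker inhibition and lower numbers for stronger inhibition:
- Compound 1 `CCCCNC(=O)COc1ccc(C(=O)c2c(CCCC)oc3ccccc23)cc1`: > 50000 nM (a limit)
- Compound 2 `CCCCc1oc2ccccc2c1C(=O)c1ccc(OCC(=O)N2CCCC2)cc1`: 42400 nM
- Compound 3 `CCCCc1oc2ccccc2c1C(=O)c1ccc(OCC(=O)N2CCN(C(=O)OC(C)(C)C)CC2)cc1`: 42200 nM

Compound 2 at 42400 nM and compound 3 at 42200 nM agree within the scatter. Compound 1 has only a limit, not a number.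

Compound 4 `CCCCc1oc2ccccc2c1C(=O)c1ccc(OCC(=O)N[C@@H](C)c2ccccc2)cc1` differs from compound 2 as follows: (1-phenylethyl)amino in place of pyrrolidin-1-yl on a carbonyl carbon. It has (1-phenylethyl)amino in place of pyrrolidin-1-yl on a carbonyl carbon. Within the data shown here, one measured step bears on this place: an at least 1.1-fold lower number from compound 1 to compound 2 (0.07 log units; that floor lies within the scatter). It gives no clear size or direction, so no step beyond the scatter is expected in this assay. The expected step is a 1.1-fold lower number from compound 2 to compound 4 (0.05 log units; within the scatter). Compound 4 is estimated at 38000 nM, with an expected range of 15000 nM to 50000 nM. Compound 4 could also end at the limit of > 50000 nM in this assay, at which 1 of the 3 values shown sits.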

Compound 4, half-maximal inhibitory concentration: 17900 nM
Estimate against measurement, compound 4: 2.1-fold (0.33 log units) above; low and high end bracket the measured number.
By their numbers in this assay, from the lowest: compound 4; then compounds 3 and 2 (each within the scatter of the next). At a limit, above all of these: compound 1.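

In this assay, this amide position shows its first change beyond the scatter, with a 2.4-fold lower number from compound 2 to compound 4 (0.37 log units; beyond the scatter). On the amide-type nitrogen, 1-phenylethyl in place of butyl gives an at least 2.7-fold lower number from compound 1 to compound 4 (0.44 log units; beyond the scatter). That step starts from a limit, not a number: the limit of > 50000 nM in this assay, at which 1 of the 4 values shown sits.

The change from compound 2 to compound 4 brings in an aromatic ring, an amide hydrogen and a defined stereocentre together, and the compounds shown do not separate these. From the compounds shown here alone, whether a benzylamino group or the mirror-image form of the 1-phenylethyl amide would give a similar number remains open.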